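Solubility of Two Measured Compounds and an Unmeasured Analogue

A few compounds are considered here, and "the series" means these few. Any claim that something is new, unique, unknown or untested is made for them only; others in the source may bear on it.

compound 1 `Cc1cc(NCc2cccnc2)n2nc(C)c(-c3ccccc3)c2n1`: 110000 nM
compound 2 `Cc1cc(NCc2ccccn2)n2ncc(-c3ccncc3)c2n1`: 161000 nM

In a physicochemical assay for solubility, read by HPLC, using the shake flask method, measured as kinetic solubility, with a stated time of 2 h, at pH 7.4 (a higher number here means a more soluble compound, a lower number a less soluble compound), compound 1 gives 110000 nM, and compound 2 gives 161000 nM; the two numbers sit within the usual scatter of each other, so compound 1 stands apart from nothing here. Compound 3 `Cc1cc(NCC2CCCCN2)n2nc(C)c(-c3ccccc3)c2n1` has not been measured. It differs from compound 1 by piperidin-2-yl in place of pyridin-3-yl on a saturated chain carbon bound to a nitrogen on an aromatic ring. Among the compounds with values here, no step between measured compounds is available to calibrate this change. Compound 3 is nonetheless expected to give a higher number in this assay than compound 1, an expected step of a 2.7-fold higher number from compound 1 to compound 3 (0.44 log units; beyond the scatter) beyond the scatter. Compound 3 is estimated at 300000 nM, with a range from 120000 nM to 750000 nM.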

Compound 3, solubility: 189000 nM
Compound 3: the middle estimate sits 1.6-fold (0.20 log units) above what was measured, within the range that was stated.
By their numbers in this assay, from the lowest: compounds 1, 2 and 3 (each within the scatter of the next).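

In this assay, within the data shown here, piperidin-2-yl in place of pyridin-3-yl on a saturated chain carbon bound to a nitrogen on an aromatic ring gives a 1.7-fold higher number from compound 1 to compound 3 (0.24 log units; within the scatter) and so supplies the first step that can be read at this position. Compound 1 and compound 3, though one carries an aromatic ring and the other a non-aromatic ring with a hydrogen-bond donor, cannot be told apart here. No measured evidence accounts for this step.

Going by these compounds, it remains open whether a morpholine ring, a carboxylic acid or a longer chain at this place would give a step beyond the scatter. On these data alone, whether the same exchange would read alike on the core of compound 2 also remains open.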